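Chloro to methoxy swap carried onto a second core

This account rests on a few compounds, and the source may have more. Where it says the series, first, only, none or still open, it means among the compounds named here.

Compound 1 `CC1(C)Cc2c(O)ccc(C(=O)/C=C/c3cn(-c4ccccc4)nc3-c3ccc(Cl)cc3)c2O1` and compound 3 `CC1(C)Cc2c(ccc(C(=O)/C=C/c3cn(-c4ccccc4)nc3-c3ccc(Cl)cc3)c2OCc2ccccc2)O1` are built on two different cores; the difference between the two cores is not broken down here. In a functional assay on PC-3 cells (Homo sapiens) for antiproliferative activity, read by MTT assay, with a stated time of 48 h (on this read-out higher numbers stand for weaker inhibition and lower numbers for stronger inhibition), compound 1 gives 18000 nM. Compound 2 `COc1ccc(-c2nn(-c3ccccc3)cc2/C=C/C(=O)c2ccc(O)c3c2OC(C)(C)C3)cc1` differs from compound 1 only by methoxy in place of chloro on an aromatic carbon; in this assay compound 2 gives 20800 nM, so that the step of a 1.2-fold higher number from compound 1 to compound 2 (0.06 log units; within the scatter). In this assay compound 3 gives 26000 nM. Compound 4 `COc1ccc(-c2nn(-c3ccccc3)cc2/C=C/C(=O)c2ccc3c(c2OCc2ccccc2)CC(C)(C)O3)cc1` has not been measured yet; it differs from compound 3 by methoxy in place of chloro on an aromatic carbon, the same change as between compound 1 and compound 2, at a place described in the same words. Among the four compounds this change occurs twice, once with both ends measured. For compound 4 the step in this assay is expected to be a 1.2-fold higher number from compound 3 to compound 4 (0.06 log units; within the scatter), which rests on the measured step of a 1.2-fold higher number from compound 1 to compound 2 (0.06 log units; within the scatter) on the other core. Compound 4 is therefore estimated at 30000 nM in this assay, with a plausible range from 15000 nM to 60000 nM.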

Compound 4, half-maximal inhibitory concentration: 18400 nM
For compound 4 the middle estimate is 1.6-fold (0.21 log units) above the measured one, within the range that was stated.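

In this assay the swap of chloro for methoxy, cut one bond further out 4-chlorophenyl to 4-methoxyphenyl, gives a 1.4-fold lower number from compound 3 to compound 4 (0.15 log units; within the scatter), so the step on this core stays inside the usual scatter. Set beside the earlier step, it does not differ from it: the same change on two cores in this assay, a 1.2-fold higher number (0.06 log units; within the scatter) from compound 1 to compound 2 and a 1.4-fold lower number (0.15 log units; within the scatter) from compound 3 to compound 4, 1.6-fold (0.21 log units) apart, within the scatter of two such steps. On these two cores and in this one read-out, the change therefore leaves the number within the scatter both times; neither step is beyond the scatter, so the carrying over of a real effect is not tested, and two pairs say nothing about other cores or other assays.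

Still open, as far as these compounds go, is whether another group at the same place, para to a large group, such as an amine or a carboxylic acid, would give a step beyond the scatter on either core. Also open, from the compounds shown here alone, is whether a longer chain in place of methoxy, such as ethoxy or propoxy, would give steps that agree between the two cores.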